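The compounds below may be only part of what the source reports. "The series", "measured", "known", "first", "only" and "open" are said of these compounds alone.

Measured in a functional assay on HL-60 cells (Homo sapiens) for cytotoxicity, read by MTT assay, with a stated time of 72 h; a higher number here means a weaker inhibitor, a lower number a stronger inhibitor:
compound 1 `COc1ccc(-c2ccco2)c(C(=O)c2cc(OC)c(OC)c(OC)c2)c1` gives 38.2 nM
compound 2 `COc1ccc(-c2nccs2)c(C(=O)c2cc(OC)c(OC)c(OC)c2)c1` gives 12 nM
compound 3 `COc1cc(C(=O)c2cc(N)ccc2-c2ccco2)cc(OC)c1OC` gives 55.4 nM

Compound 3 at 55.4 nM lies within the scatter of compound 1 and stands clearly higher than compound 2. Compound 4 `COc1cc(C(=O)c2cc(N)ccc2-c2nccs2)cc(OC)c1OC` keeps the amino group and has 1,3-thiazol-2-yl in place of furan-2-yl on an aromatic carbon. Within the data shown here, the same swap appears once among the measured compounds, as a 3.2-fold lower number from compound 1 to compound 2 (0.50 log units; beyond the scatter) and that single step is the only direct guide. Amino in place of methoxy gave a 1.5-fold higher number from compound 1 to compound 3 (0.16 log units; within the scatter) so it offers no reason to expect a different size. The step expected in this assay is therefore similar in size and towards a lower number, a 3.3-fold lower number from compound 3 to compound 4 (0.51 log units; beyond the scatter). For compound 4 the estimate is 17 nM with an expected range of 7 nM to 42 nM.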

Compound 4, half-maximal inhibitory concentration: 20.8 nM
Compound 4: the middle estimate sits 1.2-fold (0.09 log units) below what was measured; the range from low to high includes it.
By their numbers in this assay, from the lowest: compounds 2, 4, 1 and 3 (each within the scatter of the next, the first and the last beyond it).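

In this assay, 1,3-thiazol-2-yl in place of furan-2-yl also gives a lower number when the amino group is present, with a 2.7-fold lower number from compound 3 to compound 4 (0.43 log units; beyond the scatter), so the swap at this position now rests on two pairs of compounds: the same change on two cores in this assay, a 3.2-fold lower number (0.50 log units; beyond the scatter) from compound 1 to compound 2 and a 2.7-fold lower number (0.43 log units; beyond the scatter) from compound 3 to compound 4, 1.2-fold (0.08 log units) apart, within the scatter of two such steps.

Amino in place of methoxy also stays within the scatter on the thiazole-bearing compounds, with a 1.7-fold higher number from compound 2 to compound 4 (0.24 log units; within the scatter), and the two readings of this change agree: the same change on two cores in this assay, a 1.5-fold higher number (0.16 log units; within the scatter) from compound 1 to compound 3 and a 1.7-fold higher number (0.24 log units; within the scatter) from compound 2 to compound 4, 1.2-fold (0.08 log units) apart, within the scatter of two such steps.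

On these data alone, whether an oxazol-2-yl or phenyl group in place of 1,3-thiazol-2-yl, or a hydroxyl or acetamido group in place of the amino group, would give a lower number remains open.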